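A Longer Ester Chain on Compound 2

A few compounds are considered here, and "the series" means these few. Any claim that something is new, unique, unknown or untested is made for them only; others in the source may bear on it.

In a functional assay on the whole organism with Mus musculus as the target (on this read-out higher numbers stand for an effect only at larger amounts of compound and lower numbers for an effect already at smaller amounts), compound 1 (`Cc1ccccc1-c1ccc(N2CCC(O)CC2)nn1`) gives 40 mg/kg. Compound 2 (`CC(=O)OC1CCN(c2ccc(-c3ccc(Cl)cc3Cl)nn2)CC1`) gives 9.8 mg/kg, the lower of the two numbers, and the gap between them lies beyond the usual scatter. These two compounds differ in more than one place, so their gap cannot be tied to any single change. Compound 3 (`CCCC(=O)OC1CCN(c2ccc(-c3ccc(Cl)cc3Cl)nn2)CC1`) has not yet been measured. It departs from compound 2 in one place: ethyl in place of hydrogen on a saturated chain carbon bound to a carbonyl carbon, turning acetoxy into (propylcarbonyl)oxy. Among the measured compounds shown here, no measured pair shows this kind of change, and the only anchor is compound 2 at 9.8 mg/kg, so no shift beyond the scatter is expected in this assay. The estimated step is a 1.2-fold higher number from compound 2 to compound 3 (0.09 log units; within the scatter). For compound 3 the expected value is 12 mg/kg, with an estimated range of 5 mg/kg to 28 mg/kg.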

Compound 3, dose for half-maximal effect: 31 mg/kg
The estimate for compound 3 lay 2.6-fold (0.41 log units) below the measured number, outside the stated range (above it).
By their numbers in this assay, from the lowest: compound 2; then compounds 3 and 1 (each within the scatter of the next).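

In this assay this position proves sensitive: ethyl in place of hydrogen on a saturated chain carbon bound to a carbonyl carbon, turning acetoxy into (propylcarbonyl)oxy, gives a 3.2-fold higher number from compound 2 to compound 3 (0.50 log units; beyond the scatter). Among the compounds shown here, compound 1 and compound 2 differ in more than one place, so this is the first change here that can be tied to a single place, and it moves the effect toward larger amounts of compound. Nothing at hand accounts for the shift.

A single step cannot tell whether a longer chain such as pentyl would move the number further in the same direction or whether it would level off. It also leaves open how an amine or a carboxylic acid at the end of this chain would read in this assay.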